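The source may report more compounds than this note shows. Statements on the series, on what has been measured and on what is new or still open speak of the compounds shown alone.

Working notes on a small series sharing one core, followed in a functional assay on CWR22R cells (Homo sapiens) for antiproliferative activity, read by CCK-8 assay, with a stated time of 6 days; a higher number here means a weaker inhibitor, a lower number a stronger inhibitor. Compound 1 `C[C@@H](Cn1ccc(-c2ccc(C#N)c(Cl)c2)n1)NC(=O)c1ccccc1F` stands at "not determined" (no result reported) in this assay. Compound 2 `C[C@@H](Cn1ccc(-c2ccc(C#N)c(Cl)c2)n1)NC(=O)C1CC(=O)C1` likewise stands at "not determined" (no result reported), so neither offers a number for comparison. Compound 3 `C[C@@H](Cn1ccc(-c2ccc(C#N)c(Cl)c2)n1)Nc1ccccc1` gives > 30000 nM, which is a limit of the assay and not a number. The measured picture therefore comes down to the limit of > 30000 nM in this assay, at which 1 of the 3 values shown sits.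

The unmeasured compound 4 `C[C@@H](Cn1ccc(-c2ccc(C#N)c(Cl)c2)n1)Nc1cccnc1` departs from compound 3 at a single place: pyridin-3-yl in place of phenyl on an amine nitrogen. In words, this is pyridin-3-yl in place of phenyl on an amine nitrogen, the rest of the structure being unchanged. Among the measured compounds shown here, the series holds no measured step with which to size this change. The expectation therefore rests on compound 3 alone, whose limit is > 30000 nM. The expected shift, a number no higher from compound 3 to compound 4 (the limit leaves the size open), is none beyond the scatter, in either direction. A second report as a limit only is the expected outcome, and a measured number would be expected to lie close to that limit. The estimate for compound 4 is 30000 nM, with an expected range from 10000 nM to 60000 nM.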

Compound 4, half-maximal inhibitory concentration: 21600 nM
For compound 4 the middle estimate is 1.4-fold (0.14 log units) above the measured one; the range from low to high includes it.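

Pyridin-3-yl in place of phenyl on an amine nitrogen gives, in this assay, an at least 1.3-fold lower number from compound 3 to compound 4 (0.14 log units; that floor lies within the scatter). Among the compounds shown here, compound 4 gives 21600 nM, the first actual number, and it shows that this position can carry a six-membered aromatic ring with one hetero atom and still return a number, though only at the weak end of what a cell read-out of this kind reports. Compound 3 remains a limit of the assay and not a number, so the true size of the step stays unknown and the floor printed with it is all that can be said, with the series still tied to that limit: the limit of > 30000 nM in this assay, at which 1 of the 4 values shown sits.

As far as these compounds go, whether any group on this amine nitrogen moves the number well beyond the scatter remains open, for instance pyridin-4-yl, or a methoxy group or a carboxylic acid on the pyridine ring. Compound 1 and compound 2 carry no result, so the amides cannot yet be set against the amines at this position.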